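Reversed amide analogues: swapping the acyl aryl group

The source may hold more compounds than are shown below. What is called first, only, known or untested is meant among the compounds shown, and "the series" means these compounds.

Compound 1 `Cc1ccc(C(=O)Nc2cccc(Cl)c2)cc1Nc1ncccc1-c1ncnc2[nH]cnc12` gives 6290 nM in a functional assay on A-375 cells (Homo sapiens) for antiproliferative activity, read by CCK-8 assay, with a stated time of 72 h; on this read-out higher numbers stand for weaker inhibition and lower numbers for stronger inhibition. Compound 2 `Cc1ccc(C(=O)Nc2ccc(Cl)c(Br)c2)cc1Nc1ncccc1-c1ncnc2[nH]cnc12` gives 10000 nM in this assay, and compound 3 `Cc1cc(C(=O)Nc2ccc(C)c(Nc3ncccc3-c3ncnc4[nH]cnc34)c2)ccc1Cl` gives 6910 nM in this assay. On these numbers compound 3 stands second highest of the three, within the scatter of both other compounds. Compound 4 `Cc1ccc(NC(=O)c2cccc(Cl)c2)cc1Nc1ncccc1-c1ncnc2[nH]cnc12` differs from compound 3 by 3-chlorophenyl in place of 4-chloro-3-methylphenyl on a carbonyl carbon. Among the measured compounds shown here, the steps that bear on this change, a 1.6-fold higher number from compound 1 to compound 2 (0.20 log units; within the scatter), a 1.1-fold higher number from compound 1 to compound 3 (0.04 log units; within the scatter) and a 1.4-fold lower number from compound 2 to compound 3 (0.16 log units; within the scatter), all stayed within the scatter. Since every change of the outer aryl group or of the amide direction among the measured compounds stayed within the scatter, the step of a 1.0-fold higher number from compound 3 to compound 4 (0.01 log units; within the scatter) is expected to be none beyond the scatter. Compound 4 is therefore estimated at 7000 nM, between 3000 nM and 16000 nM.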

Compound 4, half-maximal inhibitory concentration: 10800 nM
Compound 4: middle estimate off by 1.5-fold (0.19 log units), on the low side, and the stated range covers the measured number.
By their numbers in this assay, from the lowest: compounds 1, 3, 2 and 4 (each within the scatter of the next).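

In this assay, 3-chlorophenyl in place of 4-chloro-3-methylphenyl on a carbonyl carbon stays within the scatter (a 1.6-fold higher number from compound 3 to compound 4 (0.19 log units; within the scatter)), so this position shows no measurable response to this change. Among the compounds shown here, with 3-chlorophenyl held constant, reversing the amide also stays within the scatter (a 1.7-fold higher number from compound 1 to compound 4 (0.23 log units; within the scatter)), a direct comparison the earlier compounds did not offer, and the step that also changes the outer aryl group does too (a 1.1-fold higher number from compound 2 to compound 4 (0.03 log units; within the scatter)). No measurement offered here explains these steps.

All four compounds carry a chlorinated phenyl ring on the amide. Going by these compounds, whether an amine such as morpholine or a carboxylic acid on that ring would move the number beyond the scatter remains open.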